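Chloro in Place of Nitro: From Compound 3 to Compound 4

A few compounds are considered here, and "the series" means these few. Any claim that something is new, unique, unknown or untested is made for them only; others in the source may bear on it.

Compound 1, `Cc1cccc(/C=N/c2ccc(OCc3ccccc3)cc2)c1O`: in a functional assay, with a stated time of 30 min (a lower number here means a stronger inhibitor, a higher number a weaker inhibitor), compound 1 gives > 200000 nM, a limit.
Compound 2, `Cc1ccc(/C=N/c2ccc(OCc3ccccc3)cc2)c(O)c1`: in this assay compound 2 gives > 200000 nM, a limit.
Compound 3, `O=[N+]([O-])c1ccc(O)c(/C=N/c2ccc(OCc3ccccc3)cc2)c1`: in this assay compound 3 gives > 200000 nM, a limit.

All three measured compounds share one core and differ only in the group on the hydroxy-bearing ring. Compound 1 and compound 2 carry methyl groups, and the step that the two limits leave unreadable from compound 1 to compound 2 cannot be read, because both ends are limits. Going by the values given here, compound 3 carries a nitro group and likewise stands only at a limit; every value so far sits at the limit of > 200000 nM in this assay, at which 3 of the 3 values shown sit, so nothing yet separates the three.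

Compound 4, `Oc1ccc(Cl)cc1/C=N/c1ccc(OCc2ccccc2)cc1`, is the next member. It differs from compound 3 by chloro in place of nitro on an aromatic carbon. Among the compounds with values here, no measured step bears on this exchange, and the one step recorded, a step that the two limits leave unreadable from compound 1 to compound 2, is itself unreadable. For compound 4 the expectation is therefore a step that the limit leaves unreadable from compound 3 to compound 4, no change that the assay could show. Compound 4 is expected to give about 300000 nM in this assay, within 50000 nM to 2000000 nM.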

Compound 4, half-maximal inhibitory concentration: > 200000 nM
Compound 4: a limit, no number; the forecaster's own chance of this, stated with the estimate: 85%; the middle value lies beyond the limit too.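

In this assay compound 4 gives > 200000 nM as a limit. Going by these compounds alone, no step from compound 1, compound 2 or compound 3 to compound 4 can be read. The compounds shown leave open whether any of these groups on the hydroxy-bearing ring changes inhibition, with every value at one limit: the limit of > 200000 nM in this assay, at which 4 of the 4 values shown sit.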